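From a Pyrrolidinylmethyl Arm to a Carbamoyl Group

The source may report more compounds than this note shows. Statements on the series, on what has been measured and on what is new or still open speak of the compounds shown alone.

For the measured compounds named here, compound 2 `CCNC(=O)c1noc(-c2cc(C(C)C)c(O)cc2O)c1-c1cc(CN2CCCC2)no1` holds the lowest of the two numbers measured so far: in a functional assay on HCT-116 cells (Homo sapiens) for inhibition (on this read-out lower numbers stand for stronger inhibition and higher numbers for weaker inhibition), compound 2 gives 51 nM. Going by the values given here, its nearest neighbour, compound 1 `CCNC(=O)c1noc(-c2cc(C(C)C)c(O)cc2O)c1-c1cc(CNC)no1`, gives 164 nM in this assay, and the single measured step, a 3.2-fold lower number from compound 1 to compound 2 (0.51 log units; beyond the scatter), came with pyrrolidin-1-yl in place of methylamino on a saturated chain carbon bound to an aromatic carbon. Compound 3 `CCNC(=O)c1noc(-c2cc(C(C)C)c(O)cc2O)c1-c1cc(C(N)=O)no1` has not yet been measured. It differs from compound 2 in one place: carbamoyl in place of (pyrrolidin-1-yl)methyl on an aromatic carbon. Among the compounds with values here, the one recorded step bears on this position, since both changes touch the same aromatic carbon of the five-membered aromatic ring with 1 nitrogen and 1 oxygen; that step was modest and ran toward stronger inhibition as the ring amine grew. Here the whole (pyrrolidin-1-yl)methyl arm leaves and a carbamoyl enters, a change the recorded step does not cover directly, so the expectation is a step in this assay of a 7.8-fold higher number from compound 2 to compound 3 (0.89 log units; beyond the scatter), toward a higher number. Compound 3 is accordingly estimated at 400 nM, with a range from 100 nM to 1600 nM.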

Compound 3, half-maximal inhibitory concentration: 79 nM
Compound 3: middle estimate off by 5.1-fold (0.70 log units), on the high side; measured number outside the range, below it.
By their numbers in this assay, from the lowest: compounds 2 and 3 (each within the scatter of the next); then compound 1.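

In this assay, carbamoyl on the aromatic carbon next to the ring nitrogen gives a 1.5-fold higher number from compound 2 to compound 3 (0.19 log units; within the scatter), so the change from a (pyrrolidin-1-yl)methyl arm with a five-membered non-aromatic ring to a smaller group with no ring leaves compound 3 within the scatter of compound 2. The change from the (methylamino)methyl arm gives a 2.1-fold lower number from compound 1 to compound 3 (0.32 log units; beyond the scatter), a modest step beyond the scatter, so among these three compounds a saturated amine arm at this position is not needed for a number at the low end of the series, and the earlier step from methylamino to pyrrolidin-1-yl alone could not show this. Nothing available here accounts for why the amine arm and carbamoyl give numbers this close.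

The compounds shown leave open how much of this result depends on carbamoyl itself, since a carboxylic acid, a nitrile or an N-methylcarbamoyl on the same aromatic carbon would each test a different part of that group. They also leave open whether carbamoylmethyl, a longer chain ending in the same group, would stay with compounds 2 and 3 or move toward compound 1.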